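A few compounds are considered here, and "the series" means these few. Any claim that something is new, unique, unknown or untested is made for them only; others in the source may bear on it.

Compound 1 `N#Cc1cnc(NCc2cnccc2C(F)(F)F)cc1N[C@H]1CC[C@@H](O)CC1` gives 100 nM
Compound 2 `N#Cc1cnc(NCc2ccccc2C(F)(F)F)cc1N[C@H]1CC[C@@H](O)CC1` gives 140 nM

Both were tested in an assay on isolated protein for inhibition of protein kinase C theta type (Homo sapiens), read by TR-FRET, with a stated time of 2 h; a lower number here means a stronger inhibitor, a higher number a weaker inhibitor. Compound 1 has the lower of the two numbers, yet compound 2 with its 140 nM sits within the scatter of compound 1, so the two cannot be told apart. Compound 3 `CO[C@H]1CC[C@@H](CNc2cc(NCc3cnccc3C(F)(F)F)ncc2C#N)CC1` differs from compound 1 in one place: (4-methoxycyclohexyl)methyl in place of 4-hydroxycyclohexyl on a nitrogen on an aromatic ring. Going by the values given here, no measured pair shows this kind of change, so its effect rests on expectation alone. A moderate weakening is expected, a 3.0-fold higher number from compound 1 to compound 3 (0.48 log units; beyond the scatter). Compound 3 is therefore estimated to give about 300 nM in this assay, with a range from 120 nM to 900 nM.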

Compound 3, half-maximal inhibitory concentration: 70 nM
For compound 3 the middle estimate is 4.3-fold (0.63 log units) above the measured one, outside the stated range (below it).
By their numbers in this assay, from the lowest: compounds 3, 1 and 2 (each within the scatter of the next).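

Putting (4-methoxycyclohexyl)methyl in place of 4-hydroxycyclohexyl on this nitrogen gives a 1.4-fold lower number from compound 1 to compound 3 (0.15 log units; within the scatter), so compound 1 and compound 3 cannot be told apart. This position therefore accepts a group with more heavy atoms and no hydrogen-bond donor without a measurable loss of inhibition. Nothing available explains this tolerance.

Going by these compounds, the change adds a methylene and a methyl at once, so the share of each remains unknown. Also open, on these data alone, is how an amine or a carboxylic acid in place of the methoxy group would behave.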